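The source may hold more compounds than are shown below. What is called first, only, known or untested is meant among the compounds shown, and "the series" means these compounds.

Measured so far, all in a functional assay on the whole organism with Rattus norvegicus as the target (a higher number here means that more compound is needed for the effect, a lower number that less compound is needed), as the read-out
compound 1 `CCCCCCc1ccc2nc(N)sc2c1` gives 7 mg/kg 
compound 2 `C=CCn1c(=N)sc2cc(OC(F)(F)F)ccc21` gives 7 mg/kg 

Compound 2 stands level with compound 1, the two values lying within the scatter of each other. Next comes compound 3 `N=c1sc2cc(OC(F)(F)F)ccc2n1CC(N)=O`, not yet measured, which differs from compound 2 in one place: carbamoyl in place of vinyl on a saturated chain carbon bound to an aromatic nitrogen in the counted terms. Among the measured compounds shown here, no measured pair shows this change, so its size rests on judgement alone. A modest rise in the dose needed is expected, though a result within the scatter would not be a surprise. The estimate amounts to a 1.7-fold higher number from compound 2 to compound 3 (0.23 log units; within the scatter) as the expected step. For compound 3 the estimated dose is 12 mg/kg with an expected range from 4 mg/kg to 35 mg/kg in this read-out.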

Compound 3, dose for half-maximal effect: 7 mg/kg
Compound 3: middle estimate off by 1.7-fold (0.23 log units), on the high side; measured number inside the range.
By their numbers in this assay, from the lowest: compounds 1, 2 and 3 (each within the scatter of the next).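

In this assay, among the compounds shown here, the step of carbamoyl in place of vinyl on a saturated chain carbon bound to an aromatic nitrogen reads no change at the digits printed from compound 2 to compound 3 (within the scatter) and is the first step available at this place. The place therefore accepts carbamoylmethyl as well as allyl in this read-out, even though carbamoyl brings a hydrogen-bond donor and a hydrogen-bond acceptor that vinyl lacks. Nothing available accounts for this result.

From the compounds shown here alone, whether a carboxylic acid, an amine or a longer chain at the same saturated chain carbon would also leave the dose number level stays open. A single step also cannot show whether this change would read the same with another group, such as a nitrile, elsewhere on the shared core.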